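The compounds below may be only part of what the source reports. "The series", "measured", "known", "first", "only" and "open" are said of these compounds alone.

Compound 3 `Cc1cc(=O)n(-c2cccc(F)c2)nc1C(=O)Nc1ccc(Oc2ncnc3c2ccn3C)c(F)c1` carries a 3-fluorophenyl group on an aromatic nitrogen of the shared core. In a functional assay on HepG2 cells (Homo sapiens) for cytotoxicity, read by MTT assay, with a stated time of 72 h (on this read-out higher numbers stand for weaker inhibition and lower numbers for stronger inhibition), compound 3 gives only a limit, > 60000 nM. Compound 2 `Cc1cc(=O)n(-c2ccccc2OC(F)(F)F)nc1C(=O)Nc1ccc(Oc2ncnc3c2ccn3C)c(F)c1` also gives only a limit in this assay, > 60000 nM. The step that the two limits leave unreadable from compound 2 to compound 3 cannot be read, as both values sit at the limit of > 60000 nM in this assay, at which 2 of the 3 values shown sit. Compound 1 `Cc1ccc(-n2nc(C(=O)Nc3ccc(Oc4ncnc5c4ccn5C)cc3)c(C)cc2=O)cc1` bears a 4-methylphenyl group on the same nitrogen and differs from compound 4 only by lacking one fluorine. In this assay compound 1 gives 33800 nM, a number rather than a limit. The change from compound 3 to compound 4 `Cc1ccc(-n2nc(C(=O)Nc3ccc(Oc4ncnc5c4ccn5C)c(F)c3)c(C)cc2=O)cc1` is 4-methylphenyl in place of 3-fluorophenyl on an aromatic nitrogen. Going by the values given here, no measured step reads this exchange directly; the only step between neighbouring compounds is bounded on both sides. Compound 4 shares its 4-methylphenyl group with compound 1, whose 33800 nM shows weak inhibition. Compound 4 is expected to give 40000 nM in this assay, within 15000 nM to 80000 nM. The step of an at least 1.5-fold lower number from compound 3 to compound 4 (0.17 log units; that floor lies within the scatter) is estimated to be modest at most.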

Compound 4, half-maximal inhibitory concentration: > 60000 nM
Compound 4: no number, only a limit; the forecaster's own chance of this, stated with the estimate: 45%; middle value at least 1.5-fold (0.17 log units) away from the limit.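

In this assay compound 4 gives only a limit, so the 4-methylphenyl group, which gave a number in compound 1, gives none here on the fluorinated compound, and the steps to compound 4 from compound 2 and compound 3 cannot be read. Going by these compounds alone, the one readable step is an at least 1.7-fold higher number from compound 1 to compound 4 (0.24 log units; that floor lies within the scatter), for fluoro in place of hydrogen on an aromatic carbon, so this exchange now has a lower bound, but that bound does not show that the fluoro changes the read-out. All three fluorinated compounds now sit at one end of the scale: the limit of > 60000 nM in this assay, at which 3 of the 4 values shown sit.

As far as these compounds go, how far compound 2, compound 3 and compound 4 lie beyond that limit stays open. So does how a compound with an amine or a carboxylic acid on the phenyl group at this nitrogen would read in this assay.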